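This account rests on a few compounds, and the source may have more. Where it says the series, first, only, none or still open, it means among the compounds named here.

Compound 3 `Cc1ccc(-n2nncc2CN2C(=O)C3(C(C#N)=C(N)Oc4c3c3nc5ccccc5nc3c3ccccc43)c3ccccc32)c(C)c1` sits at the limit of a functional assay on HepG2 cells (Homo sapiens) for antiproliferative activity, read by MTT assay, with a stated time of 48 h; a higher number here means a weaker inhibitor, a lower number a stronger inhibitor: in this assay compound 3 gives > 50000 nM, a limit and not a number. Compound 1 `N#CC1=C(N)Oc2c(c3nc4ccccc4nc3c3ccccc23)C12C(=O)N(Cc1cnnn1-c1cccc(Br)c1)c1ccccc12` also returns only a limit in this assay, > 50000 nM. Among the compounds with values here, compound 2 `N#CC1=C(N)Oc2c(c3nc4ccccc4nc3c3ccccc23)C12C(=O)N(Cc1cnnn1-c1cccc(S(N)(=O)=O)c1)c1ccccc12` is the one member of the set with a number, giving 21500 nM in this assay. Of the measured steps, an at least 2.3-fold lower number from compound 1 to compound 2 (0.36 log units; beyond the scatter) and an at least 2.3-fold higher number from compound 2 to compound 3 (0.36 log units; beyond the scatter) are readable, while there is a step that the two limits leave unreadable from compound 1 to compound 3; both limits rest on (the limit of > 50000 nM in this assay, at which 2 of the 3 values shown sit). The step under study swaps the group on the aromatic nitrogen of the five-membered aromatic ring with 3 nitrogen: 3,4-dichlorophenyl in place of 2,4-dimethylphenyl on an aromatic nitrogen, giving compound 4 `N#CC1=C(N)Oc2c(c3nc4ccccc4nc3c3ccccc23)C12C(=O)N(Cc1cnnn1-c1ccc(Cl)c(Cl)c1)c1ccccc12`. The nearest measured point of comparison is compound 1, whose 3-bromophenyl, like the 3,4-dichlorophenyl entering here, carries a halogen on the ring, and compound 1 returns only a limit. Compound 3 returns only a limit as well, so the step from it cannot be sized on the numbers in hand. Compound 4 is therefore expected to stay at or beyond the limit, with a step that the limit leaves unreadable from compound 3 to compound 4 expected to fall within the scatter if any number is read at all. The estimate for compound 4 is 60000 nM, within 20000 nM to 200000 nM.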

Compound 4, half-maximal inhibitory concentration: > 50000 nM
Compound 4 ended at the assay's limit; the forecaster's own chance of this, stated with the estimate: 70%; the middle value lies beyond the limit too.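

In this assay compound 4 gives > 50000 nM, which is a limit and not a number. Within the data shown here, the 3,4-dichlorophenyl on the aromatic nitrogen of the five-membered aromatic ring with 3 nitrogen therefore joins the 3-bromophenyl and the 2,4-dimethylphenyl at the limit, and an at least 2.3-fold higher number from compound 2 to compound 4 (0.36 log units; beyond the scatter) sets it apart from the 3-sulfamoylphenyl, so far the only group at this position that returns a number. The steps among compound 1, compound 3 and compound 4 cannot be read, so no order can be given among these three groups, and the series meets a shared ceiling: the limit of > 50000 nM in this assay, at which 3 of the 4 values shown sit.

On these data alone, it remains open whether a carboxylic acid or an amine on the phenyl ring, in place of the sulfamoyl group, would also return a number in this assay, where compound 2 gives 21500 nM. As far as these compounds go, it also remains open how far under that value any other group at this position could reach, and how far beyond the limit the three compounds that sit there lie.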